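Estimating compound 3 from a single measured neighbour

The source may hold more compounds than are shown below. What is called first, only, known or untested is meant among the compounds shown, and "the series" means these compounds.

Measured in a functional assay on SW-620 cells (Homo sapiens) for cytotoxicity, read by MTT assay, with a stated time of 72 h; a lower number here means a stronger inhibitor, a higher number a weaker inhibitor
- Compound 1 `Cc1ccc(-c2cc(/N=C3/NC(=O)CS3)cs2)cc1` gives > 50000 nM (a limit of the assay)
- Compound 2 `O=C1N/C(=N/c2csc(-c3ccc(Cl)cc3)c2)S/C1=C\c1ccc(Br)cc1` gives 700 nM

Compound 1 gives > 50000 nM, which is a limit of the assay, not a number. Going by the values given here, compound 2, at 700 nM in this assay, therefore holds the only true number so far, with no second number to rank it against.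

Compound 3 `COc1ccc(/C=C2\S/C(=N\c3csc(-c4ccc(Cl)cc4)c3)NC2=O)cc1OC` differs from compound 2 in one place, with 3,4-dimethoxyphenyl in place of 4-bromophenyl on a double-bonded chain carbon bound to a double-bonded ring carbon. Among the compounds with values here, no measured pair shows what such a swap does, so the expectation is anchored on compound 2 at 700 nM alone. A small weakening, close to the usual scatter, is expected in this assay as a 2.1-fold higher number from compound 2 to compound 3 (0.33 log units; beyond the scatter) and is held loosely. Compound 3 is estimated at 1500 nM within an expected range of 350 nM to 6000 nM.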

Compound 3, half-maximal inhibitory concentration: > 50000 nM
Compound 3 was reported as a limit; the forecaster's own chance of this, stated with the estimate: 8%; middle value at least 33-fold (1.52 log units) from the limit.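

In this assay, exchanging 4-bromophenyl for 3,4-dimethoxyphenyl on a double-bonded chain carbon bound to a double-bonded ring carbon gives an at least 71-fold higher number from compound 2 to compound 3 (1.85 log units; beyond the scatter), which shows that activity in this series depends strongly on the group held at this place.

Compound 3 gives > 50000 nM, which is a limit of the assay and not a number.

The step therefore marks only the smallest possible size of the change, and its true size cannot be read: the limit of > 50000 nM in this assay, at which 2 of the 3 values shown sit.

From the compounds shown here alone, what stays open is whether the result comes from losing the bromine or from gaining the two methoxy groups. A plain phenyl or a 4-methoxyphenyl in this place would help to separate these two readings, since each differs from compound 2 in the same single place.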